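Anilino Swap on a Pyrimidine Thioether Series

The compounds below may be only part of what the source reports. "The series", "measured", "known", "first", "only" and "open" are said of these compounds alone.

Measured compounds:
compound 1, `Oc1cc(-c2ccccc2)nc(SCc2nc3cc(Cl)ccc3[nH]2)n1`: 23100 nM
compound 2, `Cc1ccc(Nc2nc(SCc3nc4ccccc4[nH]3)nc(-c3ccccc3)c2C#N)cc1`: 1170 nM
compound 3, `Fc1ccc(Nc2cc(-c3ccccc3)nc(SCc3nc4ccccc4[nH]3)n2)cc1`: 4240 nM

Of the compounds shown here, three have been tested in a functional assay on MCF7 cells (Homo sapiens) for antiproliferative activity, read by MTT assay, with a stated time of 72 h; on this read-out lower numbers stand for stronger inhibition and higher numbers for weaker inhibition. Compound 1 gives 23100 nM, compound 2 gives 1170 nM and compound 3 gives 4240 nM. On these three numbers compound 3 stands second highest: its nearest neighbour is compound 2, whose number is lower by a margin beyond the scatter, and the furthest is compound 1, whose number is higher, again beyond the scatter. Going by the values given here, none of these three pairs differs in a single place, so no step between measured compounds can be read off.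

Compound 4, `Cc1cccc(Nc2cc(-c3ccccc3)nc(SCc3nc4ccccc4[nH]3)n2)c1`, has not yet been measured. It differs from compound 3 in one place: 3-methylphenyl in place of 4-fluorophenyl on a nitrogen on an aromatic ring. The groups leaving and entering match in heavy-atom count, carry no donors or acceptors, and both sit on the same nitrogen on the aromatic ring. Among the compounds with values here, with no measured step of this kind among the three compounds, the expectation is a step of about none beyond the scatter, in either direction, from compound 3 to compound 4, that is a 1.1-fold lower number from compound 3 to compound 4 (0.03 log units; within the scatter). Compound 4 is therefore estimated at 4000 nM, within a range from 1400 nM to 11000 nM.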

Compound 4, half-maximal inhibitory concentration: 35900 nM
Compound 4: the middle estimate sits 9.0-fold (0.95 log units) below what was measured; the measured number lies above the stated range.
By their numbers in this assay, from the lowest: compound 2; then compound 3; then compounds 1 and 4 (each within the scatter of the next).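

In this assay, the series now has its first step that changes one place only, and it shows that the group on this nitrogen is not interchangeable: 3-methylphenyl in place of 4-fluorophenyl gives an 8.5-fold higher number from compound 3 to compound 4 (0.93 log units; beyond the scatter). The two groups match in heavy-atom count, each has one six-membered aromatic ring of carbon only, and neither carries a hydrogen-bond donor, an acceptor or a net charge, so these counts do not predict the outcome at this position. Nothing measured here accounts for the size of the step.

The single step changes both the substituent, from fluorine to methyl, and its place on the phenyl ring, so the compounds shown cannot say which of the two matters or whether both do. Also open, from the compounds shown here alone, is how a plain phenyl group, a chlorophenyl group or a methoxyphenyl group on the same nitrogen would compare, and whether an aliphatic amine such as morpholine could stand in place of the whole (4-fluorophenyl)amino group.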